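Trimming an Ester to a Methoxy on a Shared Core

The source may hold more compounds than are shown below. What is called first, only, known or untested is meant among the compounds shown, and "the series" means these compounds.

Of the compounds shown here, three on one core have been tested in a functional assay on HT-29 cells (Homo sapiens) for inhibition, read by luminescence and CellTiter-Glo, with a stated time of 12 h; a higher number here means that more compound is needed for the effect, a lower number that less compound is needed. Going by the values given here, compound 1 `CCOC(=O)c1cccc(NC(=O)Nc2cc(Oc3ccc4nc(NC(=O)C5CC5)sc4c3)ccc2F)c1` gives 7740 nM in this assay, the only finished number among the three. Compound 2 `O=C(Nc1nc2ccc(Oc3ccc(F)c(NS(=O)(=O)c4cccc(C(F)(F)F)c4)c3)cc2s1)C1CC1` reaches only a limit of the assay, > 20000 nM. Compound 3 `N#Cc1c(Oc2ccc(F)c(NC(=O)c3cccc(C(F)(F)F)c3)c2)ccc2nc(NC(=O)C3CC3)sc12` also stops at a limit, > 20000 nM. Compound 1 thus stands alone with a number. The other two sit at the limit of > 20000 nM in this assay, at which 2 of the 3 values shown sit.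

Compound 4 `COc1cccc(NC(=O)Nc2cc(Oc3ccc4nc(NC(=O)C5CC5)sc4c3)ccc2F)c1` has not yet been measured. It differs from compound 1 in one place: methoxy in place of ethoxycarbonyl on an aromatic carbon. Among the compounds with values here, no measured pair differing in a single place is available, so the size of this step is open. The change is expected to shift this assay by a 1.3-fold higher number from compound 1 to compound 4 (0.11 log units; within the scatter), toward a slightly higher number, close to the scatter. Compound 4 is therefore expected near 10000 nM, between 3500 nM and 30000 nM.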

Compound 4, half-maximal effective concentration: 1370 nM
The estimate for compound 4 lay 7.3-fold (0.86 log units) above the measured number, outside the stated range (below it).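

In this assay, going by these compounds alone, methoxy in place of ethoxycarbonyl gives a 5.6-fold lower number from compound 1 to compound 4 (0.75 log units; beyond the scatter), the first step on the shared core that can be read as a number. This position on the aromatic ring therefore responds to the group it carries, and in this one pair the lower number goes with the smaller group. Nothing measured here says why the number falls.

From the compounds shown here alone, whether a still smaller group continues this direction stays open. A hydroxyl, an amine or a carboxylic acid at this place could land on either side of compound 4.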